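A Second Chloro on the Urea Phenyl Ring

This account rests on a few compounds, and the source may have more. Where it says the series, first, only, none or still open, it means among the compounds named here.

Of the compounds shown here, three share one core and have been measured in a functional assay on MKN-74 cells (Homo sapiens) for antiproliferative activity, with a stated time of 24 h; a lower number here means a stronger inhibitor, a higher number a weaker inhibitor. Compound 1 `NC(=O)c1c(NC(=O)c2ccccc2Cl)sc2c1CCN(Cc1ccc(Cl)cc1Cl)C2` gives 16300 nM. Compound 2 `NC(=O)c1c(NC(=O)c2ccccc2Cl)sc2c1CCN(Cc1cc(Cl)cc(Cl)c1)C2` gives 23700 nM, with a 1.5-fold higher number from compound 1 to compound 2 (0.16 log units; within the scatter). Compound 3 `NC(=O)c1c(NC(=O)c2ccccc2Cl)sc2c1CCN(C(=O)Nc1ccccc1Cl)C2` gives 16300 nM, level with compound 1 and together with it the lowest of the three numbers, while a 1.5-fold lower number from compound 2 to compound 3 (0.16 log units; within the scatter); none of these steps reaches beyond the scatter.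

The next compound, compound 4 `NC(=O)c1c(NC(=O)c2ccccc2Cl)sc2c1CCN(C(=O)Nc1c(Cl)cccc1Cl)C2`, differs from compound 3 by chloro in place of hydrogen on an aromatic carbon, placed ortho to a large group and meta to a chloro group. Going by the values given here, no measured step alters this phenyl ring, so the only guidance is indirect: a 1.5-fold higher number from compound 1 to compound 2 (0.16 log units; within the scatter) and no change at the digits printed from compound 1 to compound 3 (within the scatter) show that rearranging chloro groups or exchanging the whole group on the ring amine left this assay essentially untouched. The step from compound 3 to compound 4 is therefore expected to stay within the scatter, a 1.0-fold lower number from compound 3 to compound 4 (0.01 log units; within the scatter). Compound 4 is estimated at 16000 nM, expected between 6000 nM and 40000 nM.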

Compound 4, half-maximal inhibitory concentration: 24400 nM
Estimate against measurement, compound 4: 1.5-fold (0.18 log units) below; the range from low to high includes it.
By their numbers in this assay, from the lowest: compounds 1, 3, 2 and 4 (each within the scatter of the next).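

In this assay, chloro in place of hydrogen on an aromatic carbon gives a 1.5-fold higher number from compound 3 to compound 4 (0.18 log units; within the scatter). Going by these compounds alone, this is the first measured change on this phenyl ring itself, and a second chloro at this position produces no shift that can be told from the scatter. The (2,6-dichlorophenyl)carbamoyl group also cannot be separated from either dichlorobenzyl group, with a 1.0-fold higher number from compound 2 to compound 4 (0.01 log units; within the scatter) and a 1.5-fold higher number from compound 1 to compound 4 (0.18 log units; within the scatter), and no information is available to explain these results.

The compounds shown leave open whether a different group at this position, such as methoxy or an amine, would take the number beyond the scatter. They also leave open what a change to the chlorophenyl amide shared by all four compounds would do.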